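The source may report more compounds than this note shows. Statements on the series, on what has been measured and on what is new or still open speak of the compounds shown alone.

Measured in an assay on isolated protein for inhibition of Alpha glucosidase (Homo sapiens), with stated times of 5 min and 15 min, tested at 50 uM; a higher number here means more inhibition at the concentration tested (going by the name of the read-out), a lower number less inhibition: compound 1 `O=C1/C(=C/c2ccccc2)CCC/C1=C\c1ccc(Cl)cc1` gives 27.6%. Compound 2 `O=C(C1=C(O)/C(=C/c2ccc(O)c(O)c2)CCC1)c1ccccc1` gives 55.9%. Compound 3 `O=C1/C(=C/c2ccccc2)CCC/C1=C\c1ccc(Cl)c(Cl)c1` gives 48.4%.

Compound 1 stands lowest of the three, with compound 3 nearest and compound 2 furthest above it. Compound 4 `Cc1cccc(/C=C2\CCC/C(=C\c3ccccc3)C2=O)c1` differs from compound 1 by 3-methylphenyl in place of 4-chlorophenyl on a double-bonded chain carbon bound to a double-bonded ring carbon. Among the compounds with values here, the only measured step that touches this ring is a number 20.8 percentage points higher from compound 1 to compound 3 (beyond the scatter), which added a second chloro rather than exchanging chloro for methyl, so it bears only loosely on the change here. Within the data shown here, no measured pair shows a methyl on this ring, and a change of this kind is not expected to move the number beyond the scatter. Compound 4 is therefore expected to give about 30%, with a range from 10% to 55%. This expectation amounts to a step of a number 2.4 percentage points higher from compound 1 to compound 4 (within the scatter).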

Compound 4, a percentage reported as inhibition, at one concentration (the size of the read-out at that concentration, not a potency): 47.9%
For compound 4 the middle estimate is 17.9 percentage points below the measured one, within the range that was stated.
By their numbers in this assay, from the lowest: compound 1; then compounds 4, 3 and 2 (each within the scatter of the next).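

Exchanging 4-chlorophenyl for 3-methylphenyl on this double-bonded chain carbon gives a number 20.3 percentage points higher from compound 1 to compound 4 (beyond the scatter), so this position responds to a change of aromatic group even when no chloro remains on that ring. Compound 4 carries no chloro there, yet it lies within the scatter of compound 3, so a chloro on this ring is not required to reach this level of inhibition. Nothing available explains the rise.

This change alters both the group and its place on the ring, so the compounds shown cannot separate the two; 3-chlorophenyl and 4-methylphenyl would be the direct tests. Going by these compounds, the effect of an amine or a carboxylic acid on this ring also remains open.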